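Bis-indolyl acrylonitriles: second methoxy on compound 2

The compounds below may be only part of what the source reports. "The series", "measured", "known", "first", "only" and "open" are said of these compounds alone.

Measured compounds and values in a functional assay on A549 cells (Homo sapiens) for cytotoxicity, read by WST assay, with a stated time of 24 h; on this read-out lower numbers stand for stronger inhibition and higher numbers for weaker inhibition:
- compound 1, `N#C/C(=C\c1cn(Cc2ccc(Cl)cc2)c2ccccc12)C(=O)c1c[nH]c2ccccc12`: > 50000 nM.
- compound 2, `COc1ccc2[nH]cc(/C=C(\C#N)C(=O)c3c[nH]c4ccccc34)c2c1`: 6600 nM.
- compound 3, `N#C/C(=C\c1c[nH]c2cc(F)ccc12)C(=O)c1c[nH]c2cc(F)ccc12`: > 50000 nM.

Compound 1 gives a value that is a limit of the assay, not a number. Compound 3 likewise gives a value that is a limit of the assay. Among the compounds with values here, compound 2 therefore stands alone as the only measured number in this assay; the other two values sit at the limit of > 50000 nM in this assay, at which 2 of the 3 values shown sit.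

Compound 4, `COc1ccc2c(C(=O)/C(C#N)=C/c3c[nH]c4ccc(OC)cc34)c[nH]c2c1`, is not yet measured. It differs from compound 2 by methoxy in place of hydrogen on an aromatic carbon, placed on the second indole, on an aromatic carbon of a six-membered aromatic ring of carbon only, part of a fused or bridged system of two rings. With no measured step of this kind in the series, the direction of the change cannot be read from the data. The expected step is a 1.8-fold higher number from compound 2 to compound 4 (0.26 log units; within the scatter), meaning no shift beyond the scatter or a modest loss. Compound 4 is estimated at 12000 nM, with a range from 3000 nM to 50000 nM.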

Compound 4, half-maximal inhibitory concentration: 3700 nM
Compound 4: middle estimate off by 3.2-fold (0.51 log units), on the high side; measured number inside the range.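

In this assay, methoxy in place of hydrogen on an aromatic carbon of the second indole gives a 1.8-fold lower number from compound 2 to compound 4 (0.25 log units; within the scatter). This position, on a six-membered aromatic ring of carbon only, therefore takes methoxy without a shift beyond the scatter, and compound 4 still gives a measured number rather than a limit. The earlier compounds shown here could not show this, since no step of any kind could be read among them.

Compound 1 and compound 3 each stand at a limit of the assay, so their relation to the measured pair stays unread: the limit of > 50000 nM in this assay, at which 2 of the 4 values shown sit. Going by these compounds, whether an amine, a carboxylic acid or a longer chain at this same carbon would keep a measurable number remains open, as does the effect of methoxy at any other carbon of this ring.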